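The source may hold more compounds than are shown below. What is called first, only, known or untested is meant among the compounds shown, and "the series" means these compounds.

Compounds measured in a functional assay on A549 cells (Homo sapiens) for inhibition, read by MTT assay, with a stated time of 48 h; a lower number here means a stronger inhibitor, a higher number a weaker inhibitor:

- compound 1 `CCn1c(/C=C2\SC(=O)N(CC(=O)N3CCCCC3)C2=O)nc2ccccc21`: > 50000 nM
- compound 2 `Cn1c(/C=C2\SC(=O)N(CC(=O)N3CCCCC3)C2=O)nc2ccccc21`: > 50000 nM
- compound 3 `CC(C)n1c(/C=C2\SC(=O)N(CC(=O)N3CCCC3)C2=O)nc2ccccc21`: > 50000 nM

Each of these entries is a limit of the assay and not a number. Compound 3 therefore has no exact position in the series, and the whole measured set reads as the limit of > 50000 nM in this assay, at which 3 of the 3 values shown sit.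

Compound 4 `CC(C)n1c(/C=C2\SC(=O)N(CC(=O)N3CCCCC3)C2=O)nc2ccccc21` is the next compound to read. It differs from compound 3 by one change: piperidin-1-yl in place of pyrrolidin-1-yl on a carbonyl carbon. The change sits on a carbonyl carbon, and the rest of the structure stays the same.

Within the data shown here, the only measured step, a step that the two limits leave unreadable from compound 1 to compound 2, lies elsewhere in the structure and gives no size to carry over. Compound 1 and compound 2 already carry piperidin-1-yl, and neither gives a number in this assay. Among the measured compounds shown here, no measured step shows this exchange directly.

The expected a number no higher from compound 3 to compound 4 (the limit leaves the size open) is none beyond the scatter, with no direction favoured. Another reading at the limit is the likeliest outcome. For compound 4 the estimated value is 50000 nM, with an expected range of 20000 nM to 100000 nM.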

Compound 4, half-maximal inhibitory concentration: 28200 nM
The estimate for compound 4 lay 1.8-fold (0.25 log units) above the measured number; the measured number falls inside the stated range.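

In this assay compound 4 gives 28200 nM, the only exact number among the compounds shown. Piperidin-1-yl on the carbonyl carbon together with isopropyl on the aromatic nitrogen is thus the one pairing here that comes off the limit. The amide exchange gives an at least 1.7-fold lower number from compound 3 to compound 4 (0.24 log units; that floor lies within the scatter), while the changes on the aromatic nitrogen give an at least 1.7-fold lower number from compound 2 to compound 4 (0.24 log units; that floor lies within the scatter) and an at least 1.7-fold lower number from compound 1 to compound 4 (0.24 log units; that floor lies within the scatter). All three are floors rather than sizes, none reaches beyond the scatter, and the set still sits mostly at one limit: the limit of > 50000 nM in this assay, at which 3 of the 4 values shown sit.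

From the compounds shown here alone, the true size of each step stays open, with the three limit compounds giving no number to set against compound 4. Also open, going by these compounds, is whether morpholin-4-yl on the carbonyl carbon, or a longer chain on the aromatic nitrogen, would move the number beyond the scatter.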